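This account rests on a few compounds, and the source may have more. Where it says the series, first, only, none or still open, it means among the compounds named here.

In a functional assay on HCT-116 cells (Homo sapiens) for antiproliferative activity, read by MTT assay, with a stated time of 48 h (on this read-out lower numbers stand for stronger inhibition and higher numbers for weaker inhibition), three analogues built on a shared core have been tested. Compound 1, with structure `COc1ccc2nc(Nc3ccnc(Nc4ccc(S(N)(=O)=O)cc4)n3)sc2c1`, gives 1480 nM in this assay. Compound 3, with structure `Cc1ccc2nc(Nc3ccnc(Nc4ccc(S(C)(=O)=O)cc4)n3)sc2c1`, gives 1750 nM in this assay, a number that sits within the usual scatter of the value for compound 1, so the two cannot be ranked against each other. Compound 2, with structure `NS(=O)(=O)c1ccc(Nc2ncc(F)c(Nc3nc4ccccc4s3)n2)cc1`, gives 3260 nM in this assay, which lies beyond the scatter relative to compound 1; compound 1 therefore holds the lowest of the three numbers, but only the gap to compound 2 can be called a real difference.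

Compound 4, with structure `NS(=O)(=O)c1ccc(Nc2nccc(Nc3nc4ccc(F)cc4s3)n2)cc1`, has not yet been measured in this assay. It differs from compound 1 in a single place: fluoro in place of methoxy on an aromatic carbon. Within the data shown here, no step between measured compounds isolates this change, so no directly comparable precedent exists. Given that compound 1 gives 1480 nM and that the three measured compounds span only a narrow band, the step from compound 1 to compound 4 is expected to be small, at most a modest weakening, and quite possibly none beyond the scatter; the expected step is a 1.4-fold higher number from compound 1 to compound 4 (0.13 log units; within the scatter). Compound 4 is accordingly expected to give about 2000 nM in this assay, with a plausible range from 900 nM to 4500 nM.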

Compound 4, half-maximal inhibitory concentration: 700 nM
Estimate against measurement, compound 4: 2.9-fold (0.46 log units) above; measured number outside the range, below it.
By their numbers in this assay, from the lowest: compound 4; then compounds 1, 3 and 2 (each within the scatter of the next, the first and the last beyond it).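

In this assay, fluoro in place of methoxy on an aromatic carbon gives a 2.1-fold lower number from compound 1 to compound 4 (0.33 log units; beyond the scatter), a modest step but one that lies beyond the scatter. This is the first single-place comparison among these compounds, since no two of the earlier ones differed in only one place, and it shows that the group on this carbon of the fused ring system can shift the antiproliferative read-out, with the smaller fluoro giving the lower number of the pair. Nothing shown here bears on why the number falls with this exchange, and a single step cannot say which difference between methoxy and fluoro matters.

The compounds shown leave open how other groups on this same carbon would compare, for instance chloro, an amine, a hydroxyl or a longer chain such as ethoxy. They also leave open whether the step from methoxy to fluoro would keep its direction and size if the methylsulfonyl group replaced the sulfonamide elsewhere on the shared core.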